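Aryl swap on the chain carbon: expectation for compound 3

The source may report more compounds than this note shows. Statements on the series, on what has been measured and on what is new or still open speak of the compounds shown alone.

Two compounds carry the shared core with a different aryl group on a double-bonded chain carbon bound to a double-bonded chain carbon. Compound 1 `Cc1ccc(/C=C/C(=O)c2ccccc2NC(=O)NS(=O)(=O)c2ccc(C)cc2)cc1` gives 15.3 ug/mL in an ADME assay on the whole organism for cytotoxicity, with Artemia salina as the target, with a stated time of 24 h; a higher number here means that more compound is needed for the effect, a lower number that less compound is needed. Compound 2 `Cc1ccc(S(=O)(=O)NC(=O)Nc2ccccc2C(=O)/C=C/c2ccccc2Cl)cc1` gives 12.8 ug/mL in this assay. The step of a 1.2-fold lower number from compound 1 to compound 2 (0.08 log units; within the scatter) is within the scatter, so compound 2, although it shows the smaller of the two numbers, cannot be told apart from compound 1 on these data.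

Compound 3 `Cc1ccc(S(=O)(=O)NC(=O)Nc2ccccc2C(=O)/C=C/c2cccnc2)cc1` differs from compound 2 by pyridin-3-yl in place of 2-chlorophenyl on a double-bonded chain carbon bound to a double-bonded chain carbon. Within the data shown here, the only measured step that bears on this change is the aryl exchange at the same place, a 1.2-fold lower number from compound 1 to compound 2 (0.08 log units; within the scatter), which did not move the number beyond the scatter. Among the measured compounds shown here, no measured step involves a nitrogen-containing aryl at this place, so the expectation rests on that single comparison alone. A step of the kind a 1.0-fold higher number from compound 2 to compound 3 (0.01 log units; within the scatter) is expected, that is, none beyond the scatter. Compound 3 is therefore estimated at 13 ug/mL in this assay, with a range from 6 ug/mL to 28 ug/mL.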

Compound 3, concentration for half-maximal effect: 14.1 ug/mL
Beside the measured number, compound 3's estimate is 1.1-fold (0.04 log units) below it; the range from low to high includes it.
By their numbers in this assay, from the lowest: compounds 2, 3 and 1 (each within the scatter of the next).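

The exchange of 2-chlorophenyl for pyridin-3-yl, which brings in one six-membered aromatic ring with 1 hetero atom and 1 hydrogen-bond acceptor, gives a 1.1-fold higher number from compound 2 to compound 3 (0.04 log units; within the scatter) in this assay, and the exchange of 4-methylphenyl for the same group gives a 1.1-fold lower number from compound 1 to compound 3 (0.04 log units; within the scatter). The place on a double-bonded chain carbon bound to a double-bonded chain carbon therefore now holds a ring with a hetero atom as well as the two carbon-only rings, and compound 1, compound 2 and compound 3 cannot be told apart in this assay, with none of the three going against that reading. Nothing shown here gives a measured reason for this lack of separation.

The compounds shown leave open whether the number stays this close with a carboxylic acid or an amine on the aryl ring, or with a thienyl ring at this place. They also leave open what happens when a longer saturated carbon chain replaces the whole 2-(pyridin-3-yl)ethenyl group.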